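Methyl capping of the phenol on compound 2

The compounds below may be only part of what the source reports. "The series", "measured", "known", "first", "only" and "open" are said of these compounds alone.

Compound 2 `O=C(Nc1cccc(-n2cc(-c3ccncc3)c(-c3cc(O)cc(Cl)c3)n2)c1)Nc1ccc(Cl)c(Cl)c1` is measured in a functional assay on SF-268 cells (Homo sapiens) for inhibition, read by sulforhodamine B assay, with a stated time of 48 h, tested at 0.1 uM (on this read-out lower numbers stand for a stronger effect and higher numbers for a weaker effect at the one concentration tested), at 98%. Compound 1 `O=C(Nc1cccc(-n2cc(-c3ccncc3)c(-c3cc(O)cc(Cl)c3)n2)c1)Nc1ccc(Cl)c(C(F)(F)F)c1` gives 93% in this assay, and compound 3 `COc1cc(Cl)cc(-c2nn(-c3cccc(NC(=O)Nc4cc(C(F)(F)F)cc(C(F)(F)F)c4)c3)cc2-c2ccncc2)c1` gives 99%. Compound 2 thus stands second highest of the three numbers, with compound 3 nearest and compound 1 furthest, both inside the scatter, so no order among the three can be read.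

Compound 4 `COc1cc(Cl)cc(-c2nn(-c3cccc(NC(=O)Nc4ccc(Cl)c(Cl)c4)c3)cc2-c2ccncc2)c1` differs from compound 2 by one change: methyl in place of hydrogen on an oxygen on an aromatic ring. Cut one bond further out, this reads hydroxy to methoxy on the 3-chloro-5-hydroxyphenyl group. For the measured compounds named here, no measured step covers exactly this change. Going by the values given here, the one measured step, a number 5 percentage points higher from compound 1 to compound 2 (within the scatter), concerns a different position and lies inside the scatter. Compound 3 already carries the methoxy group beside a different urea substituent and shows 99%, which offers no sign of a shift beyond the scatter.

Compound 4 is therefore expected at 98%, within 90% to 105%, a step of no change at the digits printed from compound 2 to compound 4 (within the scatter) that is expected to stay within the scatter.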

Compound 4, a percentage reported as activity, at one concentration (the size of the read-out at that concentration, not a potency): 95%
Estimate against measurement, compound 4: 3 percentage points above, and the stated range covers the measured number.
By their numbers in this assay, from the lowest: compounds 1, 4, 2 and 3 (each within the scatter of the next).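

In this assay, for the compounds shown here, the change from hydroxy to methoxy gives a number 3 percentage points lower from compound 2 to compound 4 (within the scatter) and so places a direct matched pair on this position, where the earlier compounds offered only a methoxy compound with a different urea substituent. With the 3,4-dichlorophenyl urea held constant, methyl can take the place of hydrogen on this oxygen without a step that can be read at the one concentration tested. No measurement shown here gives a reason for this result.

From the compounds shown here alone, whether an ethyl chain on this oxygen, or an amine in place of the hydroxy group, would give a step beyond the scatter remains open. So does whether hydroxy and methoxy would separate at another concentration, as a single concentration gives no potency for either compound.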